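Removing the Fluorophenyl Arm From Compound 3

The source may report more compounds than this note shows. Statements on the series, on what has been measured and on what is new or still open speak of the compounds shown alone.

Measured compounds in an assay on cells for inhibition of Voltage-dependent T-type calcium channel subunit alpha-1G (Homo sapiens), read by patch clamp, tested at 10 uM; on this read-out higher numbers stand for more inhibition at the one concentration tested (going by the name of the read-out) and lower numbers for less inhibition:
compound 1 `CN(C)CCCCCSC1=Nc2ccccc2C(CC(=O)NCc2ccc(F)cc2)N1c1ccc(-c2ccccc2)cc1` gives 31%
compound 2 `CN(C)CCCCCSC1=Nc2ccccc2C(CC(=O)NCc2ccccc2)N1c1ccccc1` gives 46.5%
compound 3 `CN(C)CCCCCSC1=Nc2ccccc2C(CC(=O)NCc2ccc(F)cc2)N1c1ccc(-c2ccc(F)cc2)cc1` gives 96.2%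

Compound 3 stands highest of the three in this assay; compound 2 comes nearest, and compound 1 lies furthest off, both gaps beyond the scatter. Compound 4 `CN(C)CCCCCSC1=Nc2ccccc2C(CC(=O)NCc2ccc(F)cc2)N1c1ccccc1` differs from compound 3 in one place: hydrogen in place of 4-fluorophenyl on an aromatic carbon. Within the data shown here, the only single-change step measured, a number 65.2 percentage points higher from compound 1 to compound 3 (beyond the scatter), shows that the fluorine on that arm carries most of the inhibition of compound 3, and compound 4 loses the whole arm. Compound 4 also shares its core with compound 2, whose value is 46.5%, and the two differ only in the fluorine on the benzyl amide. A large fall is therefore expected, a number 56.2 percentage points lower from compound 3 to compound 4 (beyond the scatter). Compound 4 is estimated at 40%, with a range from 15% to 68%.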

Compound 4, a percentage reported as inhibition, at one concentration (the size of the read-out at that concentration, not a potency): 26.7%
The estimate for compound 4 lay 13.3 percentage points above the measured number; the range from low to high includes it.
By their numbers in this assay, from the lowest: compounds 4 and 1 (each within the scatter of the next); then compound 2; then compound 3.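

On this aromatic carbon the arm counts only with its fluorine: removing the 4-fluorophenyl gives a number 69.5 percentage points lower from compound 3 to compound 4 (beyond the scatter), whereas removing the plain phenyl gives a number 4.3 percentage points lower from compound 1 to compound 4 (within the scatter). Fluoro in place of hydrogen also goes the opposite way on the benzyl amide, with a number 19.8 percentage points lower from compound 2 to compound 4 (beyond the scatter). The direction of this change therefore depends on where it is made: the same change on two cores in this assay, a number 65.2 percentage points higher (beyond the scatter) from compound 1 to compound 3 and a number 19.8 percentage points lower (beyond the scatter) from compound 2 to compound 4, 85 percentage points apart, beyond the scatter of two such steps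

The compounds shown leave open whether a 4-chlorophenyl or 4-methoxyphenyl arm would match the 4-fluorophenyl. They also leave open whether the arm's fluorine keeps its gain when the benzyl amide carries no fluorine.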